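This account rests on a few compounds, and the source may have more. Where it says the series, first, only, none or still open, it means among the compounds named here.

Compound 1 `CCCCNc1nc(N)nc(C)c1CCCN(C)C` gives 126 nM in an assay on HEK293 cells for agonist activity at Toll-like receptor 8 (Homo sapiens), read by spectrophotometry (a higher number here means that more compound is needed for the effect, a lower number that less compound is needed), the lowest of the three numbers available. Compound 2 `CCCC#Cc1c(C)nc(N)nc1NCCCC` gives 5000 nM and compound 3 `C#Cc1c(C)nc(N)nc1NCCCC` gives 4900 nM. Both of those carry a triple bond where compound 1 carries its 3-(dimethylamino)propyl chain, and the steps were large: a 40-fold higher number from compound 1 to compound 2 (1.60 log units; beyond the scatter) and a 39-fold higher number from compound 1 to compound 3 (1.59 log units; beyond the scatter), while a 1.0-fold lower number from compound 2 to compound 3 (0.01 log units; within the scatter). Compound 4 `CCCCNc1nc(N)nc(C)c1CCCN1CCCC1` keeps that chain and differs from compound 1 only at its end: pyrrolidin-1-yl in place of dimethylamino on a saturated chain carbon, three bonds along the chain from an aromatic carbon. Among the compounds with values here, no measured step alters the amine itself, so the large steps do not bear directly on this change; they only show that removing the chain costs much. Compound 4 is therefore expected to stay close to compound 1, with a 1.1-fold lower number from compound 1 to compound 4 (0.02 log units; within the scatter) within the scatter. The estimate for compound 4 is 120 nM, ranging from 50 nM to 300 nM.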

Compound 4, half-maximal effective concentration: 110 nM
Compound 4: the middle estimate sits 1.1-fold (0.04 log units) above what was measured, within the range that was stated.
By their numbers in this assay, from the lowest: compounds 4 and 1 (each within the scatter of the next); then compounds 3 and 2 (each within the scatter of the next).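

Swapping dimethylamino for pyrrolidin-1-yl on this chain, a ring of 5 heavy atoms in place of 3 heavy atoms, makes no real difference in this assay, with a 1.1-fold lower number from compound 1 to compound 4 (0.06 log units; within the scatter). The earlier steps shown here showed only that losing the whole chain is costly, whereas this one shows that the end of the chain accepts a five-membered ring. No measurement here explains this tolerance. As far as these compounds go, how far it extends stays open: a larger ring such as piperidin-1-yl, or a chain ending in a hydroxyl group with no nitrogen, could read differently.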